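The source may report more compounds than this note shows. Statements on the series, on what has been measured and on what is new or still open speak of the compounds shown alone.

Measured compounds:
- compound 1, `CCCCC(C)(C)[C@H](O)/C=C/[C@H]1CCC(=O)N1CCSc1nc(C(=O)O)cs1`: 8.4 nM
- compound 2, `CC(C)(C)CCC1([C@H](O)/C=C/[C@H]2COC(=O)N2CCSc2nc(C(=O)O)cs2)CCC1`: 6.7 nM
- compound 3, `CC(C)(CCCCF)[C@H](O)/C=C/[C@H]1COC(=O)N1CCSc1nc(C(=O)O)cs1`: 4.7 nM

All three were tested in an assay on isolated protein for agonist activity at prostaglandin E2 receptor EP3 subtype (Homo sapiens); a higher number here means that more compound is needed for the effect, a lower number that less compound is needed. The number for compound 1 is the largest of the three, yet its gaps to compound 2 and compound 3 both fall within the usual scatter, so the three compounds cannot be told apart on these data.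

Compound 4, `CCCC[C@H](C)C[C@H](O)/C=C/[C@H]1CCC(=O)N1CCSc1nc(C(=O)O)cs1`, has not yet been measured. It differs from compound 1 in one place: 2-methylhexyl in place of 1,1-dimethylpentyl on a saturated chain carbon bound to a double-bonded chain carbon and an oxygen on a saturated carbon. The same atoms are present in both, only joined differently, so the branched chain beside the alcohol carbon is rearranged rather than enlarged or shrunk.

Within the data shown here, only one measured step touches this same place, the change a 1.4-fold lower number from compound 2 to compound 3 (0.15 log units; within the scatter). There, a much larger rearrangement of the chain at the same position moved the number no further than the scatter. On that basis the step from compound 1 to compound 4 is expected to stay small as well, with no clear direction, and the estimated change is a 1.1-fold higher number from compound 1 to compound 4 (0.03 log units; within the scatter).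

Compound 4 is therefore estimated to give 9 nM in this assay, with a likely range from 4 nM to 20 nM.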

Compound 4, half-maximal effective concentration: 310 nM
For compound 4 the middle estimate is 34-fold (1.54 log units) below the measured one, and the stated range ends below it.
By their numbers in this assay, from the lowest: compounds 3, 2 and 1 (each within the scatter of the next); then compound 4.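

Rearranging the branches of the chain, with no atom added or lost, gives a 37-fold higher number from compound 1 to compound 4 (1.57 log units; beyond the scatter) in this assay. At this position, on a saturated chain carbon bound to a double-bonded chain carbon and an oxygen on a saturated carbon, the way the chain is joined therefore matters, and not only which atoms it contains. The earlier step, a 1.4-fold lower number from compound 2 to compound 3 (0.15 log units; within the scatter), exchanged 1-(3,3-dimethylbutyl)cyclobutyl for 5-fluoro-1,1-dimethylpentyl, two groups whose names both place their branching at the 1 of the chain, as does 1,1-dimethylpentyl in compound 1, so it could not show this.

Nothing measured here explains why the number changes so much for this rearrangement. As far as these compounds go, it also remains open whether the change follows from losing the branching at the 1 of the chain or from gaining a methyl at the 2, and whether the mirror-image form of the 2-methylhexyl group would behave like compound 4; an unbranched heptyl chain, a 1-methylhexyl group and that mirror-image form would help to separate these possibilities.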